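A few compounds are considered here, and "the series" means these few. Any claim that something is new, unique, unknown or untested is made for them only; others in the source may bear on it.

Among the compounds with values here, compound 3, with the structure `Cc1ccc(/C=C2\S/C(=N\c3csc(-c4ccc(Cl)cc4)c3)NC2=O)cc1`, is the one compound in this set that gives an actual number: in a functional assay on MCF7 cells (Homo sapiens) for cytotoxicity, read by MTT assay, with a stated time of 72 h (on this read-out lower numbers stand for stronger inhibition and higher numbers for weaker inhibition), compound 3 gives 900 nM. Compound 1, with the structure `Cc1ccc(-c2cc(/N=C3/NC(=O)CS3)cs2)cc1`, gives only a limit of the assay, > 50000 nM. Compound 2, with the structure `O=C1CS/C(=N\c2csc(-c3ccccc3)c2)N1`, likewise gives only a limit, > 50000 nM. Within the data shown here, the single measured step, a step that the two limits leave unreadable from compound 1 to compound 2, cannot be read in size because of the limit of > 50000 nM in this assay, at which 2 of the 3 values shown sit. Both compounds that sit at that limit lack the double-bonded chain carbon that carries an aromatic ring in compound 3, so the shared core on its own gives no readable number in this assay.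

Compound 4, with the structure `O=C1N/C(=N/c2csc(-c3ccc(Cl)cc3)c2)S/C1=C\c1ccccn1`, differs from compound 3 in one place: pyridin-2-yl in place of 4-methylphenyl on a double-bonded chain carbon bound to a double-bonded ring carbon. Among the measured steps none touches the group on that double-bonded chain carbon, so there is no measured comparison that bears directly on this change. Among the measured compounds shown here, the only guide is the measured value of compound 3, since compound 3 carries the same core and the same chlorophenyl group. For the measured compounds named here, the expectation is therefore a step close to none beyond the scatter, a 1.7-fold higher number from compound 3 to compound 4 (0.22 log units; within the scatter), with wide uncertainty because no step in the data speaks to this position. For compound 4 the estimated value is 1500 nM, within a range from 300 nM to 8000 nM.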

Compound 4, half-maximal inhibitory concentration: 30200 nM
The estimate for compound 4 lay 20-fold (1.30 log units) below the measured number; measured number outside the range, above it.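

The group on the double-bonded chain carbon bound to a double-bonded ring carbon has a large effect on this read-out: in this assay, putting pyridin-2-yl in place of 4-methylphenyl gives a 34-fold higher number from compound 3 to compound 4 (1.53 log units; beyond the scatter) and leaves every other atom of the molecule unchanged. Both groups are six-membered aromatic rings, so an aromatic ring at this place is not enough in itself to keep the number of compound 3; what changes is that the methyl leaves, a ring nitrogen enters, and one hydrogen-bond acceptor comes with it. Within the data shown here, the earlier compounds could not show any of this, as none carries a group at this place and their one step cannot be read: (the limit of > 50000 nM in this assay, at which 2 of the 4 values shown sit).

The compounds shown do not separate the loss of the methyl from the arrival of the ring nitrogen, and a plain phenyl group at this place would be the direct comparison for both. They also leave open how this position would respond to an amine or a carboxylic acid on that aromatic ring.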